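The source may report more compounds than this note shows. Statements on the series, on what has been measured and on what is new or still open speak of the compounds shown alone.

Measured so far:
- compound 1, `COC(=O)c1ccc(/N=N/N(C)C)cc1`: 3.2
- compound 2, `CN(C)/N=N/c1ccc(S(N)(=O)=O)cc1C(N)=O`: 3.32

Both compounds share the same core and were tested in a functional assay on L1210 cells (Mus musculus) for antiproliferative activity; a higher number here means a more potent compound, by a factor of ten per unit of this negative logarithm, a lower number a less potent compound. Compound 1 gives 3.2 there, and compound 2 gives 3.32. Compound 1 holds the lowest of the two numbers, but its nearest neighbour, compound 2, lies only a small way off, within the scatter, so the two compounds cannot be told apart on this evidence.

The unmeasured compound 3, `CN(C)/N=N/c1ccc(NC(N)=O)cc1`, is obtained from compound 1 by a single change on the aromatic carbon para to a group of 5 heavy atoms: ureido in place of methoxycarbonyl on an aromatic carbon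

For the measured compounds named here, no pair of measured compounds differs in one place, so no measured step is available to guide this one. Going by the values given here, the two numbers known for the core fall close together, and the change from compound 1 to compound 3 is an exchange of one small substituent for another of equal atom count. The step of a number 0.10 log units higher from compound 1 to compound 3 (within the scatter) is therefore expected to be modest and to stay within the scatter, with no clear direction. For compound 3 in this assay the estimate is 3.3, with a range from 2.8 to 3.8.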

Compound 3, logarithm of the reciprocal of the active concentration, log(1/C): 3.97
The estimate for compound 3 lay 0.67 log units below the measured number, outside the stated range (above it).
By their numbers in this assay, from the lowest: compounds 1 and 2 (each within the scatter of the next); then compound 3.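

For the compounds shown here, the exchange of methoxycarbonyl for ureido on this aromatic carbon, para to a group of 5 heavy atoms, gives the first single-place comparison in this assay, and the result is a number 0.77 log units higher from compound 1 to compound 3 (beyond the scatter). Both groups count 4 heavy atoms and carry 1 double bond outside aromatic rings, so this position is not indifferent to which group it carries even when the heavy-atom count stays the same, something the two earlier compounds, which differ in more than one place, could not show; what does change in the counts is that the entering ureido has 2 hydrogen-bond donors and 1 hydrogen-bond acceptor, where the leaving methoxycarbonyl has 0 and 2. Nothing available bears on why the number rises with this exchange.

On these data alone, whether an amine, a carboxylic acid or an acetamido group on this carbon would stand nearer compound 1 or compound 3 stays open. So does whether a longer chain on the ureido group would keep the higher number, since a single step gives no trend.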